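This account rests on a few compounds, and the source may have more. Where it says the series, first, only, none or still open, it means among the compounds named here.

Compound 1 `CCn1c(C(=O)N(CCC#N)CCC#N)ccc1C(CC)(CC)c1ccc(OCCC(O)(CC)CC)c(C)c1` is the anchor of this small set. Going by the values given here, in an ADME assay on L02 cells (Homo sapiens) for antiproliferative activity, read by MTT assay, with a stated time of 48 h (a lower number here means a stronger inhibitor, a higher number a weaker inhibitor), compound 1 gives 37800 nM, and it is the only compound here with a plain number rather than a limit of the assay. Compound 2 `C#CC(C)OC(=O)c1ccc(C(CC)(CC)c2ccc(OCCC(O)(CC)CC)c(C)c2)n1CC` is recorded at a limit of the assay, > 50000 nM. Compound 3 `CCC(C)C(NC(=O)c1ccc(C(CC)(CC)c2ccc(OCCC(O)(CC)CC)c(C)c2)n1CC)C(=O)OC` likewise sits at a limit of the assay, > 50000 nM. Both steps away from compound 1 therefore read as floors only: an at least 1.3-fold higher number from compound 1 to compound 2 (0.12 log units; that floor lies within the scatter), and an at least 1.3-fold higher number from compound 1 to compound 3 (0.12 log units; that floor lies within the scatter). This is summed up by the limit of > 50000 nM in this assay, at which 2 of the 3 values shown sit.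

Compound 4 `CCOC(=O)C(CC(=O)OC)NC(=O)c1ccc(C(CC)(CC)c2ccc(OCCC(O)(CC)CC)c(C)c2)n1CC` is not yet measured. It differs from compound 1 by a group of 12 heavy atoms (7 carbon, 1 nitrogen, 4 oxygen; no ring) in place of a group of 9 heavy atoms (6 carbon, 3 nitrogen; no ring), on a carbonyl carbon. Among the compounds with values here, the closest measured step is the one to compound 3, which also places an amide bearing an ester on the carbonyl carbon. That step reached the limit of the assay, so a number at or beyond the limit is expected for compound 4 as well, an estimated 1.7-fold higher number from compound 1 to compound 4 (0.24 log units; within the scatter) in this assay. Compound 4 is expected to give about 65000 nM, within a range from 30000 nM to 160000 nM.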

Compound 4, half-maximal inhibitory concentration: 4280 nM
For compound 4 the middle estimate is 15-fold (1.18 log units) above the measured one, and the stated range ends above it.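

At this carbonyl carbon, the choice of group can now be seen to change the result in this assay by more than the scatter: an 8.8-fold lower number from compound 1 to compound 4 (0.95 log units; beyond the scatter). An amide bearing an ester is not enough on its own to give a weak result, as changing only the group on the amide-type nitrogen gives an at least 11-fold lower number from compound 3 to compound 4 (1.06 log units; beyond the scatter), and the group of 12 heavy atoms also gives an at least 11-fold lower number from compound 2 to compound 4 (1.06 log units; beyond the scatter). These last two steps are floors rather than exact sizes, because the starting compound in each is recorded only at a limit: the limit of > 50000 nM in this assay, at which 2 of the 4 values shown sit.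

The compounds shown do not tell which of the two esters in compound 4 matters for this change. As far as these compounds go, whether a carboxylic acid in place of either ester, or a longer chain on the amide-type nitrogen, would keep the lower number also stays open.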